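The compounds below may be only part of what the source reports. "The series", "measured", "known", "first", "only" and "open" are said of these compounds alone.

Four compounds in this study share one core and differ only in a single group on a carbon-only six-membered aromatic ring. Compound 1 `CC(C)OC(=O)c1ccc(NCc2cncn2Cc2ccc(-c3ccccc3)cc2)cc1-c1ccccc1` carries an isopropoxycarbonyl there, compound 2 `O=C(OC1CCCCC1)c1ccc(NCc2cncn2Cc2ccc(-c3ccccc3)cc2)cc1-c1ccccc1` a cyclohexyloxycarbonyl, and compound 3 `c1ccc(-c2ccc(Cn3cncc3CNc3ccc(N4CCCC4)c(-c4ccccc4)c3)cc2)cc1` a pyrrolidin-1-yl. In a toxicity assay on NIH3T3 cells (Mus musculus) for cytotoxicity, read by resazurin assay (on this read-out higher numbers stand for an effect only at larger amounts of compound and lower numbers for an effect already at smaller amounts), compound 3 reaches only a limit, > 1000 nM. Compound 1 also gives a limit in this assay, > 10000 nM. Compound 2 likewise gives a limit, > 10000 nM. With every end a limit, the steps a step that the two limits leave unreadable from compound 1 to compound 3 and a step that the two limits leave unreadable from compound 2 to compound 3 stay unreadable, as does a step that the two limits leave unreadable from compound 1 to compound 2. Compound 3 stands at the limit of > 1000 nM in this assay, at which 1 of the 3 values shown sits, the lower of the two limits seen. Compound 4 `CCOC(=O)c1ccc(NCc2cncn2Cc2ccc(-c3ccccc3)cc2)cc1-c1ccccc1` is not yet measured; it differs from compound 3 by ethoxycarbonyl in place of pyrrolidin-1-yl on an aromatic carbon. This makes compound 4 an ester like compound 1 and compound 2, which both sit at the limit of > 10000 nM in this assay, at which 2 of the 3 values shown sit. Compound 4 is therefore expected to behave like them, with an estimated step that the limit leaves unreadable from compound 3 to compound 4 toward an effect only at larger amounts, and a limit is again the likely report. Compound 4 is estimated at 20000 nM, within a range from 7000 nM to 60000 nM.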

Compound 4, half-maximal effective concentration: > 10000 nM
Compound 4 was reported as a limit; the forecaster's own chance of this, stated with the estimate: 85%; the middle value does not contradict the limit.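

Among the compounds shown here, compound 4 ends in a limit, as do compound 1, compound 2 and compound 3, so no step from compound 4 to any of them can be read. The compounds shown leave open at what amount each would reach half-maximal effect in this assay.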